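Amino for hydrogen on the sulfonyl aryl of compound 3

The compounds below may be only part of what the source reports. "The series", "measured", "known", "first", "only" and "open" are said of these compounds alone.

Measured so far:
Compound 1, `COc1ccc(S(=O)(=O)Nc2cccc3ccc(C)nc23)c([N+](=O)[O-])c1`, in an assay on OCI-Ly3 cells for activation of NF-kappa-B inhibitor alpha (Homo sapiens), read by a luciferase reporter; on this read-out higher numbers stand for an effect only at larger amounts of compound and lower numbers for an effect already at smaller amounts: "not determined" (no result reported).
Compound 2, `COc1cc(NS(=O)(=O)c2ccc(C)cc2[N+](=O)[O-])c2nc(C)ccc2c1`, in this assay: > 10000 nM, a limit of the assay.
Compound 3, `COc1cc(NS(=O)(=O)c2ccc(C)cc2)c2nc(C)ccc2c1`, in this assay: 20000 nM.

Going by the values given here, compound 3 carries the only real number in the set. Compound 2 stops at a limit of the assay and compound 1 has no result, so compound 3 stands alone and cannot be ranked against either. Among the compounds with values here, the one step between measured compounds, a step that the limit leaves unreadable from compound 2 to compound 3, is not readable in size, its size being hidden by the limit of > 10000 nM in this assay, at which 1 of the 3 values shown sits.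

Compound 4, `COc1cc(NS(=O)(=O)c2ccc(C)cc2N)c2nc(C)ccc2c1`, is the next entry for this assay. It differs from compound 3 by amino in place of hydrogen on an aromatic carbon. Within the data shown here, no measured step carries this same change; the one recorded step touches the same aromatic carbon, but with its size unknown it gives no direction to lean on. The expectation therefore is no step beyond the usual scatter, that is, an expected step of no change at the digits printed from compound 3 to compound 4 (within the scatter) from compound 3 to compound 4, with the possibility that the assay again returns only a limit kept in view. For compound 4 the estimate is 20000 nM, expected to fall between 7000 nM and 60000 nM.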

Compound 4, half-maximal effective concentration: 9400 nM
Beside the measured number, compound 4's estimate is 2.1-fold (0.33 log units) above it; measured number inside the range.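

Amino in place of hydrogen on the 4-methylphenyl gives a 2.1-fold lower number from compound 3 to compound 4 (0.33 log units; beyond the scatter) in this assay, the first step of readable size in the series. This aromatic carbon, ortho to a large group, therefore responds to substitution, though the change is modest and rests on a single pair of compounds. Amino in place of nitro at the same carbon gives an at least 1.0-fold lower number from compound 2 to compound 4 (0.02 log units; that floor lies within the scatter), so this comparison puts no order on the two groups, and the step with hydrogen in place of nitro remains unreadable, the nitro compound being held at a limit of the assay: the limit of > 10000 nM in this assay, at which 1 of the 4 values shown sits.

Still open, on these data alone, is whether the step belongs to the amino group in particular or would also come with other groups on this carbon, which a hydroxy, an acetamido or a dimethylamino group there could test. Also open, as far as these compounds go, is how far the step carries over to other cores, as compound 1 has no result and offers no comparison in this assay.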